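The source may hold more compounds than are shown below. What is called first, only, known or untested is meant among the compounds shown, and "the series" means these compounds.

Compound 1 `O=C(Nc1ccc(Oc2ccnc3[nH]ccc23)c(F)c1)c1cc2cccnc2n(-c2ccccc2)c1=O` gives 190 nM in a functional assay on A549 cells (Homo sapiens) for antiproliferative activity, read by MTT assay, with a stated time of 72 h; a lower number here means a stronger inhibitor, a higher number a weaker inhibitor. Going by the values given here, compound 2 `O=C(Nc1ccc(Oc2ccnc3[nH]ccc23)c(F)c1)c1cc2cccnc2n(-c2ccc(F)c(Cl)c2)c1=O` gives 630 nM in this assay, and the change of a 3.3-fold higher number from compound 1 to compound 2 (0.52 log units; beyond the scatter) puts compound 2 at the higher of the two numbers measured so far, with compound 1 as its nearest neighbour.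

Compound 3 `O=C(Nc1ccc(Oc2ccnc3[nH]ccc23)c(F)c1)c1cc2cccnc2n(-c2ccc(Br)cc2F)c1=O` is not yet measured. It differs from compound 2 by 4-bromo-2-fluorophenyl in place of 3-chloro-4-fluorophenyl on an aromatic nitrogen. Among the compounds with values here, the only measured step that bears on this position is a 3.3-fold higher number from compound 1 to compound 2 (0.52 log units; beyond the scatter), which shows that a halogen-bearing phenyl in place of a bare phenyl moved the number by a modest amount and beyond the scatter. The step from compound 2 to compound 3 keeps a di-halogenated phenyl on that nitrogen and only rearranges the halogens, so nothing measured indicates a direction for it. The expectation is therefore a step of a 1.1-fold lower number from compound 2 to compound 3 (0.02 log units; within the scatter), within the scatter, with a wide band to cover either direction. On that basis compound 3 is expected to give about 600 nM in this assay, estimated to fall between 250 nM and 1500 nM.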

Compound 3, half-maximal inhibitory concentration: 460 nM
Compound 3: middle estimate off by 1.3-fold (0.12 log units), on the high side, and the stated range covers the measured number.
By their numbers in this assay, from the lowest: compound 1; then compounds 3 and 2 (each within the scatter of the next).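

Swapping 3-chloro-4-fluorophenyl for 4-bromo-2-fluorophenyl on the aromatic nitrogen gives a 1.4-fold lower number from compound 2 to compound 3 (0.14 log units; within the scatter) in this assay and so does not separate these two di-halogenated phenyl groups, even though both the identity of one halogen and the halogen positions differ. The second comparison with the bare phenyl, a 2.4-fold higher number from compound 1 to compound 3 (0.38 log units; beyond the scatter), lies beyond the scatter and in the same direction as the step to compound 2, so a higher number than that of compound 1 no longer rests on a single halogenated phenyl; among the three compounds shown, neither di-halogenated example goes against this. Nothing available explains either step.

The compounds shown do not separate the contribution of the bromine from that of the fluorine, and they leave open whether a single halogen on the phenyl would already produce the shift seen against compound 1. Also open, going by these compounds, is how a phenyl carrying a methoxy group or an amine, or a cyclopropyl group in place of the phenyl on that nitrogen, would read in this assay against the bare phenyl of compound 1.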